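Swapping Sulfur for Selenium in Compound 4

The compounds below may be only part of what the source reports. "The series", "measured", "known", "first", "only" and "open" are said of these compounds alone.

Compound 1, `COc1ccc(CNc2nc([Se]C)nc3ccccc23)cc1`, gives > 100000 nM in a functional assay on HT-29 cells (Homo sapiens) for cytotoxicity, read by MTT assay, with a stated time of 72 h; a higher number here means a weaker inhibitor of growth, a lower number a stronger inhibitor of growth.
Compound 2, `CSc1ccc(CNc2nc([SeH])nc3ccccc23)cc1`, gives > 100000 nM.
Compound 3, `Sc1nc(NCc2ccccc2)c2ccccc2n1`, gives 63500 nM.

Of these, only compound 3 yields an actual number. The result for compound 1 is a limit of the assay. The result for compound 2 is likewise a limit of the assay. Most of what is known here is therefore (the limit of > 100000 nM in this assay, at which 2 of the 3 values shown sit), and compound 3 stands as the one measured point.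

Compound 4, `[SeH]c1nc(NCc2ccccc2)c2ccccc2n1`, is not yet measured. It differs from compound 3 by one selenium atom in place of one sulfur atom, on an aromatic carbon. Within the data shown here, no step between measured compounds covers this change; compound 2, which also carries the selenium group, reached only the limit. The step from compound 3 to compound 4 is expected to be a 1.9-fold higher number from compound 3 to compound 4 (0.28 log units; within the scatter), toward weaker growth inhibition. Compound 4 is expected to give about 120000 nM, within 40000 nM to 350000 nM, and may itself end as a limit of this assay.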

Compound 4, concentration for total growth inhibition: > 100000 nM
Compound 4 ended at the assay's limit; the forecaster's own chance of this, stated with the estimate: 60%; the middle value is on the limit's open side.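

On this aromatic carbon, between two ring nitrogen atoms, the change from sulfur to selenium can now be read directly in this assay: it gives an at least 1.5-fold higher number from compound 3 to compound 4 (0.19 log units; that floor lies within the scatter), so selenium brings no gain in growth inhibition here. Compound 4 gives a limit of the assay rather than a number, and the selenium-bearing compounds shown all end there: the limit of > 100000 nM in this assay, at which 3 of the 4 values shown sit. The step from compound 2 to compound 4 cannot be read.

Still open, as far as these compounds go, is how far beyond its limit compound 4 truly lies. Also open, from the compounds shown here alone, is how an amine or a hydroxyl group at this position would compare with sulfanyl in this assay.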